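Hexyl chain replacing the aryl group on the exocyclic alkene

A few compounds are considered here, and "the series" means these few. Any claim that something is new, unique, unknown or untested is made for them only; others in the source may bear on it.

In a functional assay on MCF7 cells (Homo sapiens) for cytotoxicity, read by MTT assay, with a stated time of 72 h (a lower number here means a stronger inhibitor, a higher number a weaker inhibitor), compound 1 `Cc1ccc(/C=C2\S/C(=N\c3csc(-c4ccc(Cl)cc4)c3)NC2=O)cc1` gives 900 nM and compound 2 `CN(C)c1ccc(/C=C2\S/C(=N\c3csc(-c4ccc(Cl)cc4)c3)NC2=O)cc1` gives 400 nM; the step of a 2.3-fold lower number from compound 1 to compound 2 (0.35 log units; beyond the scatter) leaves compound 2 with the lowest of the two numbers. Compound 3 `CCCCCC/C=C1\S/C(=N\c2csc(-c3ccc(Cl)cc3)c2)NC1=O` carries hexyl in place of 4-(dimethylamino)phenyl on a double-bonded chain carbon bound to a double-bonded ring carbon. Among the compounds with values here, the only measured step, a 2.3-fold lower number from compound 1 to compound 2 (0.35 log units; beyond the scatter), exchanged substituents on a retained ring; no measured step removes the ring itself, so nothing bears directly on this change. The expected step is a 6.3-fold higher number from compound 2 to compound 3 (0.80 log units; beyond the scatter), toward a higher number and beyond the scatter. Compound 3 is estimated at 2500 nM, within 700 nM to 9000 nM.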

Compound 3, half-maximal inhibitory concentration: > 50000 nM
Compound 3: only a limit was reported; the forecaster's own chance of this, stated with the estimate: 10%; middle value at least 20-fold (1.30 log units) from the limit.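

Within the data shown here, at this position, on a double-bonded chain carbon bound to a double-bonded ring carbon, the earlier compounds varied only a substituent on a retained aromatic ring. Hexyl in place of that ring gives an at least 120-fold higher number from compound 2 to compound 3 (2.09 log units; beyond the scatter) and an at least 55-fold higher number from compound 1 to compound 3 (1.74 log units; beyond the scatter). The reading for compound 3 in this assay is a limit and not a number: the limit of > 50000 nM in this assay, at which 1 of the 3 values shown sits. In these compounds, then, a substituted phenyl ring at this position goes with a measurable value, and hexyl does not. Open, on these data alone, is whether the ring or the chain decides this: a cyclohexyl group, a benzyl group or a shorter chain would separate the two.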